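Thiophen-2-yl for phenyl on the imine carbon

The source may hold more compounds than are shown below. What is called first, only, known or untested is meant among the compounds shown, and "the series" means these compounds.

Compound 1 `CN1CCN(c2ccc(Nc3ncc(/N=C/c4ccccc4)c(NC4CCCC4)n3)cc2)CC1` and compound 3 `CC(C)Nc1nc(Nc2ccc(N3CCN(C)CC3)cc2)ncc1/N=C/c1ccccc1` share one core and differ only in the change (isopropyl in place of cyclopentyl on a nitrogen on an aromatic ring). In a functional assay on HeLa cells (Homo sapiens) for antiproliferative activity, read by MTT assay (on this read-out lower numbers stand for stronger inhibition and higher numbers for weaker inhibition), compound 1 reaches only the limit of the assay, > 100000 nM. Compound 3 also stops at the limit of the assay, > 100000 nM. The step that the two limits leave unreadable from compound 1 to compound 3 cannot be read, since both values sit at the limit of > 100000 nM in this assay, at which 2 of the 3 values shown sit.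

Compound 2 `CN1CCN(c2ccc(Nc3ncc(/N=C/c4cccs4)c(NC4CCCC4)n3)cc2)CC1` is compound 1 with the change (thiophen-2-yl in place of phenyl on a carbon with a double bond to nitrogen). In this assay compound 2 gives 25700 nM, a real number rather than a limit. The step of an at least 3.8-fold lower number from compound 1 to compound 2 (0.59 log units; beyond the scatter) lies beyond the scatter, though its true size is hidden by the limit of compound 1.

Compound 4 `CC(C)Nc1nc(Nc2ccc(N3CCN(C)CC3)cc2)ncc1/N=C/c1cccs1` has not been measured. It differs from compound 3 by thiophen-2-yl in place of phenyl on a carbon with a double bond to nitrogen, the same change at the same place as in the pair above. Compound 4 is expected to show an at least 2.5-fold lower number from compound 3 to compound 4 (0.39 log units; beyond the scatter), because the same change gave an at least 3.8-fold lower number from compound 1 to compound 2 (0.59 log units; beyond the scatter). Compound 4 is estimated at 40000 nM in this assay, between 15000 nM and 100000 nM, with a fair chance that only a limit is reported again.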

Compound 4, half-maximal inhibitory concentration: 77100 nM
Compound 4: the middle estimate sits 1.9-fold (0.28 log units) below what was measured; low and high end bracket the measured number.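

On the core of compound 3, thiophen-2-yl in place of phenyl on a carbon with a double bond to nitrogen gives an at least 1.2-fold lower number from compound 3 to compound 4 (0.11 log units; that floor lies within the scatter), so in this assay a real gain on this core is neither established nor excluded. Set beside the first case, the carry-over can be judged only this far: the same change on two cores in this assay, an at least 3.8-fold lower number (0.59 log units; beyond the scatter) from compound 1 to compound 2 and an at least 1.2-fold lower number (0.11 log units; that floor lies within the scatter) from compound 3 to compound 4; the limit leaves it open whether they differ. Both thiophen-2-yl compounds give real numbers rather than limits, which fits a change that carries over in direction but shows nothing about its size, and the size may depend on the core, since isopropyl in place of cyclopentyl on a nitrogen on an aromatic ring gives a 3.0-fold higher number from compound 2 to compound 4 (0.48 log units; beyond the scatter) in this one pair.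

The true size of both thiophen steps stays hidden, and the step between the two phenyl compounds cannot be read: the limit of > 100000 nM in this assay, at which 2 of the 4 values shown sit. Still open, going by these compounds, is whether a longer chain on that nitrogen, or an amine or a carboxylic acid on the thiophen-2-yl ring, would shift these numbers.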